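The source may report more compounds than this note shows. Statements on the series, on what has been measured and on what is new or still open speak of the compounds shown alone.

Compound 1 `Cc1ccc(-n2cc(CNC(=O)c3cccc4c3cnn4C(C)C)nn2)cc1`: in a functional assay on MGC-803 cells (Homo sapiens) for inhibition, read by MTT assay, with a stated time of 72 h (a higher number here means a weaker inhibitor, a lower number a stronger inhibitor), compound 1 gives > 40000 nM, which is a limit of the assay and not a number.
Compound 2 `CC(C)n1ncc2c(C(=O)NCc3cn(-c4ccccc4F)nn3)cccc21`: in this assay compound 2 gives > 40000 nM, again a limit of the assay.
Compound 3 `CC(C)n1ncc2c(C(=O)NCc3cn(-c4ccc(C(F)(F)F)cc4)nn3)cccc21`: in this assay compound 3 gives > 40000 nM, also a limit of the assay.

Compound 3 therefore stands nowhere distinct within the series: the limit of > 40000 nM in this assay, at which 3 of the 3 values shown sit, so none of the three can be ordered against the others. The steps a step that the two limits leave unreadable from compound 1 to compound 2, a step that the two limits leave unreadable from compound 1 to compound 3 and a step that the two limits leave unreadable from compound 2 to compound 3 are all unreadable for the same reason, and none of them bears a size that could be carried forward.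

Compound 4 `CC(C)n1ncc2c(C(=O)NCc3cn(Cc4ccccc4)nn3)cccc21` differs from compound 3 in one place: benzyl in place of 4-(trifluoromethyl)phenyl on an aromatic nitrogen. Within the data shown here, no measured step on the group borne by the aromatic nitrogen gives a readable size, so no direction can be taken from them; the only guide is that every variation of that group so far has left the value at the limit.

Compound 4 is expected to give 40000 nM in this assay, with a range from 15000 nM to 100000 nM. The expected step is a number no higher from compound 3 to compound 4 (the limit leaves the size open), most likely again reported as a limit rather than a number.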

Compound 4, half-maximal inhibitory concentration: 14300 nM
Estimate against measurement, compound 4: 2.8-fold (0.45 log units) above, outside the stated range (below it).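

Benzyl on the aromatic nitrogen gives the only readable movement at this position in this assay, with an at least 2.7-fold lower number from compound 3 to compound 4 (0.44 log units; beyond the scatter), an at least 2.7-fold lower number from compound 2 to compound 4 (0.44 log units; beyond the scatter) and an at least 2.7-fold lower number from compound 1 to compound 4 (0.44 log units; beyond the scatter). Of the four compounds, only compound 4 comes off the limit, while the substituted phenyl groups of compound 1, compound 2 and compound 3 do not: the limit of > 40000 nM in this assay, at which 3 of the 4 values shown sit.

Each of these steps gives only a lower bound on its size, and the steps among compound 1, compound 2 and compound 3 cannot be read.

Going by these compounds, whether the lower number is particular to benzyl or extends to a longer chain such as 2-phenylethyl stays open. Also open, on these data alone, is how a benzyl carrying an amine or a carboxylic acid on its ring would read out in this assay.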